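Aniline swap on the shared core of compound 3

A few compounds are considered here, and "the series" means these few. Any claim that something is new, unique, unknown or untested is made for them only; others in the source may bear on it.

Three compounds share one core and differ only in their aryl groups. Compound 1 `O=C(CSc1nc(Nc2ccccc2)c2ccccc2n1)Nc1ccc(Br)cc1` gives 11500 nM in a functional assay on MDA-MB-231 cells (Homo sapiens) for inhibition, read by MTT assay, with a stated time of 72 h; on this read-out higher numbers stand for weaker inhibition and lower numbers for stronger inhibition. Compound 2 `O=C(CSc1nc(Nc2ccccc2)c2ccccc2n1)Nc1ccc(Cl)cc1Cl` gives 19400 nM in this assay, the step being a 1.7-fold higher number from compound 1 to compound 2 (0.23 log units; within the scatter). Compound 3 `C=CC(=O)Nc1cccc(NC(=O)CSc2nc(Nc3ccccc3Br)c3ccccc3n2)c1` gives 15200 nM in this assay. Among these three numbers compound 3 lies between compound 1 and compound 2, and all three readings fall within the usual scatter of one another, so no ranking among them is supported.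

Compound 4 `C=CC(=O)Nc1cccc(NC(=O)CSc2nc(Nc3cccc(OC)c3)c3ccccc3n2)c1` differs from compound 3 by 3-methoxyphenyl in place of 2-bromophenyl on a nitrogen on an aromatic ring. Within the data shown here, no measured step touches this position: the single measured step, that from compound 1 to compound 2, concerns the amide-type nitrogen and itself stayed within the scatter. It gives no direct guide to the aniline side beyond showing that the aryl changes tried so far have left this assay unmoved. The step of a 1.0-fold lower number from compound 3 to compound 4 (0.01 log units; within the scatter) is therefore expected to remain within the scatter, with no direction claimed. Compound 4 is estimated at 15000 nM in this assay. For compound 4 the lower end of the estimate is expected to be 6000 nM and the upper end of the estimate is expected to be 40000 nM.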

Compound 4, half-maximal inhibitory concentration: 12900 nM
Compound 4: the middle estimate sits 1.2-fold (0.07 log units) above what was measured; the range from low to high includes it.
By their numbers in this assay, from the lowest: compounds 1, 4, 3 and 2 (each within the scatter of the next).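

Among these compounds, this is the first measured change on the aniline side of the series: in this assay, 3-methoxyphenyl in place of 2-bromophenyl on a nitrogen on an aromatic ring gives a 1.2-fold lower number from compound 3 to compound 4 (0.07 log units; within the scatter). Within this pair, the read-out therefore shows no response to losing the bromine-bearing ring and gaining a methoxy-bearing ring with its hydrogen-bond acceptor, although the group and its place on the ring change together, so neither can be read alone. Nothing available bears on why the number holds across this swap.

Going by these compounds, it remains open whether any group on this aryl ring can move the number beyond the scatter; an amine, a carboxylic acid or a longer chain in place of the methoxy group would address that. Also open, on these data alone, is how the plain phenyl on this nitrogen, as carried by compound 1 and compound 2, would read with the rest of compound 3 kept unchanged, which would separate the contribution of the bromine from that of the methoxy group.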